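The source may report more compounds than this note shows. Statements on the series, on what has been measured and on what is new or still open speak of the compounds shown alone.

Measured so far in an assay on isolated protein for inhibition of malate dehydrogenase, mitochondrial (Sus scrofa), with stated times of 45 min and 30 min; a higher number here means a weaker inhibitor, a lower number a stronger inhibitor:
Compound 1 `CS(=O)(=O)Nc1ccc2oc(-c3ccccc3)nc2c1` gives > 63000 nM, which is a limit of the assay and not a number.
Compound 2 `O=S(=O)(Nc1ccc(-c2nc3ccccc3o2)cc1)c1ccccc1F` gives > 63000 nM, also a limit.
Compound 3 `COc1ccccc1S(=O)(=O)Nc1ccc(-c2nc3ccccc3o2)cc1` gives > 63000 nM, also a limit.

Going by the values given here, compound 1 thus stands at the limit, and the limit of > 63000 nM in this assay, at which 3 of the 3 values shown sit, places every value shown there, so no compound can be ordered against another. Among the compounds with values here, the only step between neighbours, a step that the two limits leave unreadable from compound 2 to compound 3, is unreadable. The new compound 4 `O=S(=O)(Nc1ccc2oc(-c3ccccc3)nc2c1)c1cccc(Cl)c1` differs from compound 1 in this way: 3-chlorophenyl in place of methyl on a sulfonyl sulfur. Within the data shown here, no measured step bears on this change. With every value shown a limit, the step expected here, a step that the limit leaves unreadable from compound 1 to compound 4, has no readable direction or size. Compound 4 is estimated at 80000 nM, within 30000 nM to 200000 nM, and is expected most likely to remain at the limit too.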

Compound 4, half-maximal inhibitory concentration: > 63000 nM
Compound 4: only a limit was reported; the forecaster's own chance of this, stated with the estimate: 75%; the middle value is on the limit's open side.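

No step can be read between compound 1 and compound 4: both results are limits of the assay, not numbers. The compounds shown leave open whether any change to these structures gives a measurable value in this assay.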